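A piperidinyl group enters where hydrogen gave the lowest number

The source may hold more compounds than are shown below. What is called first, only, known or untested is meant among the compounds shown, and "the series" means these compounds.

Compound 3 `c1ccc2c(-c3cocn3)c[nH]c2c1` gives 103000 nM in a functional assay on MIA PaCa-2 cells (Homo sapiens) for cytotoxicity, read by MTT assay, with a stated time of 48 h (a lower number here means a stronger inhibitor, a higher number a weaker inhibitor), the lowest of the three numbers recorded. Compound 1 `Cc1nc(-c2c[nH]c3ccccc23)co1` gives 689000 nM, and compound 2 `Clc1ccc(-c2nc(-c3c[nH]c4ccccc34)co2)cc1` gives 326000 nM. For the measured compounds named here, the steps that bear on the new change are a 6.7-fold lower number from compound 1 to compound 3 (0.83 log units; beyond the scatter) and a 3.2-fold lower number from compound 2 to compound 3 (0.50 log units; beyond the scatter), both of them removing a group from the same aromatic carbon; the related step of a 2.1-fold lower number from compound 1 to compound 2 (0.33 log units; beyond the scatter) swapped one group for another there. Compound 4 `c1ccc2c(-c3coc(C4CCNCC4)n3)c[nH]c2c1` goes the other way, with piperidin-4-yl in place of hydrogen on an aromatic carbon. Because a 6.7-fold lower number from compound 1 to compound 3 (0.83 log units; beyond the scatter) and a 3.2-fold lower number from compound 2 to compound 3 (0.50 log units; beyond the scatter) both lowered the number when a group left this carbon, a modest rise is expected when one enters: a 2.4-fold higher number from compound 3 to compound 4 (0.39 log units; beyond the scatter). Compound 4 is therefore estimated at 250000 nM, within a range from 80000 nM to 800000 nM.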

Compound 4, half-maximal inhibitory concentration: 230000 nM
Compound 4: middle estimate off by 1.1-fold (0.04 log units), on the high side; measured number inside the range.
By their numbers in this assay, from the lowest: compound 3; then compounds 4 and 2 (each within the scatter of the next); then compound 1.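

In this assay, piperidin-4-yl joins methyl and 4-chlorophenyl in giving a higher number than hydrogen on this aromatic carbon (a 2.2-fold higher number from compound 3 to compound 4 (0.35 log units; beyond the scatter)), so hydrogen remains lowest of the four. A non-aromatic ring with a ring nitrogen cannot be told apart from 4-chlorophenyl here (a 1.4-fold lower number from compound 2 to compound 4 (0.15 log units; within the scatter)), while both give lower numbers than methyl (a 3.0-fold lower number from compound 1 to compound 4 (0.48 log units; beyond the scatter)). As far as these compounds go, whether an open-chain amine such as aminomethyl or a carboxylic acid on this carbon would fall below hydrogen remains open. Nothing measured here explains these steps.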